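The compounds below may be only part of what the source reports. "The series", "measured", "known", "first", "only" and "open" are said of these compounds alone.

For the measured compounds named here, in a functional assay on HL-60 cells (Homo sapiens) for inhibition, read by CCK-8 assay, with a stated time of 48 h (on this read-out lower numbers stand for stronger inhibition and higher numbers for weaker inhibition), only two compounds have been tested so far. Compound 1 (`Cc1cc(C)cc(NC(=O)NCCNS(=O)(=O)c2ccc(-c3ccccc3OCc3cccc(O)c3)s2)c1`) gives > 20000 nM and this is a limit of the assay and not a number. Compound 2 (`Nc1ccc(Oc2ccccc2-c2ccc(S(=O)(=O)NCCNC(=O)Nc3cc(C(F)(F)F)cc(C(F)(F)F)c3)s2)cc1`) gives > 50000 nM and this too is a limit and not a number. Going by the values given here, compound 2 therefore stands at a limit, as does the only other compound measured, and neither offers an actual figure to work from. Compound 3 (`O=C(NCCNS(=O)(=O)c1ccc(-c2ccccc2OCc2ccccc2)s1)Nc1cc(C(F)(F)F)cc(C(F)(F)F)c1`) differs from compound 2 in one place, with benzyl in place of 4-aminophenyl on an oxygen on an aromatic ring. Among the compounds with values here, no measured step shows what this swap does. The estimated at least 3.3-fold lower number from compound 2 to compound 3 (0.52 log units; beyond the scatter) is a modest move toward stronger inhibition, and it is expected with considerable doubt. Compound 3 is expected at 15000 nM with an estimated range from 3000 nM to 50000 nM around that figure.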

Compound 3, half-maximal inhibitory concentration: 11400 nM
Estimate against measurement, compound 3: 1.3-fold (0.12 log units) above; the range from low to high includes it.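

In this assay, placing benzyl in place of 4-aminophenyl on this oxygen gives an at least 4.3-fold lower number from compound 2 to compound 3 (0.64 log units; beyond the scatter). Both groups hold one six-membered aromatic ring of carbon only, so even this small exchange at the position moves the read-out beyond the usual scatter and yields a real figure rather than a limit. The full size of the step stays unknown, since compound 2 stands at a limit and not a number: the limit of > 50000 nM in this assay, at which 1 of the 3 values shown sits.

The compounds shown do not separate the loss of the amine from the added carbon between the oxygen and the ring, a question that a plain phenyl or a 4-aminobenzyl on the oxygen would address. They also leave open how a carboxylic acid or a longer chain at this position would read in this assay.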